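The source may report more compounds than this note shows. Statements on the series, on what has been measured and on what is new or still open speak of the compounds shown alone.

Compound 1, `COc1cc(-c2nnc3n2NC(c2ccco2)C(C(=O)c2cccc(Br)c2)S3)cc(OC)c1OC`, in a functional assay on HepG2 cells (Homo sapiens) for cytotoxicity, read by MTT assay, with a stated time of 48 h (on this read-out higher numbers stand for weaker inhibition and lower numbers for stronger inhibition), gives > 100000 nM, which is a limit of the assay rather than a number.
Compound 2, `COc1cc(-c2nnc3n2NC(c2ccco2)C(C(=O)c2ccc(C)cc2)S3)cc(OC)c1OC`, in this assay gives 17400 nM.
Compound 3, `COc1cc(-c2nnc3n2NC(c2ccco2)C(C(=O)c2ccccc2F)S3)cc(OC)c1OC`, in this assay gives > 100000 nM, again a limit of the assay and not a number.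

Compound 3 therefore stands at the weak edge of what has been measured, sharing the limit of > 100000 nM in this assay, at which 2 of the 3 values shown sit, with another compound. Of the three measured steps, an at least 5.7-fold higher number from compound 2 to compound 3 (0.75 log units; beyond the scatter) can be read, whereas a step that the two limits leave unreadable from compound 1 to compound 3 cannot be sized, since both of its ends are limits. Going by the values given here, the remaining step, an at least 5.7-fold lower number from compound 1 to compound 2 (0.75 log units; beyond the scatter), is the first one seen from the other side.

Compound 4, `COc1cc(-c2nnc3n2NC(c2ccco2)C(C(=O)c2ccccc2)S3)cc(OC)c1OC`, differs from compound 3 by hydrogen in place of fluoro on an aromatic carbon. Among the compounds with values here, none of the measured steps makes this particular exchange: each swaps one substituted phenyl for another on the carbonyl carbon, so the effect of the plain phenyl is untested here. With two of the three measured compounds at the limit and only compound 2 showing a number, the expectation for compound 4 is a weak result near the limit. The estimate for compound 4 is 60000 nM, with a range from 15000 nM to 200000 nM, which corresponds to an expected step of an at least 1.6-fold lower number from compound 3 to compound 4 (0.22 log units; that floor lies within the scatter).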

Compound 4, half-maximal inhibitory concentration: 90900 nM
Compound 4: middle estimate off by 1.5-fold (0.18 log units), on the low side, within the range that was stated.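

Going to the plain phenyl gives an at least 1.1-fold lower number from compound 3 to compound 4 (0.04 log units; that floor lies within the scatter), and likewise an at least 1.1-fold lower number from compound 1 to compound 4 (0.04 log units; that floor lies within the scatter), so neither halogen can be said to have made compound 3 or compound 1 any weaker than the unsubstituted ring. The methyl group, by contrast, now has a direct comparison, with a single exchange on the ring giving a 5.2-fold higher number from compound 2 to compound 4 (0.72 log units; beyond the scatter). Compound 2 is thus the strongest of the four in this assay, with its steps to all the others beyond the scatter, while the plain phenyl of compound 4 stays at the weak end with the two halogen compounds, close to where the assay stops giving numbers: the limit of > 100000 nM in this assay, at which 2 of the 4 values shown sit.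

From the compounds shown here alone, whether a 4-methoxyphenyl, a 4-ethylphenyl or a 4-aminophenyl on the carbonyl would match the 4-methylphenyl remains open, so it is unclear whether this gain belongs to the methyl group alone. The step between compound 1 and compound 3 cannot be read, since both of its ends are limits.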